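The source may hold more compounds than are shown below. What is called first, only, known or untested is meant among the compounds shown, and "the series" means these compounds.

Of the compounds shown here, three that share one core have been tested in a functional assay on the whole organism for antagonist activity, with Mus musculus as the target; on this read-out lower numbers stand for an effect already at smaller amounts and higher numbers for an effect only at larger amounts of compound. Compound 1 `COc1cc(N)c(Cl)cc1NC(=O)C1CCN(Cc2cccc(C)c2)CC1` gives 2.4 mg/kg. Compound 2 `COc1cc(N)c(Cl)cc1NC(=O)C1CCN(Cc2ccccc2Cl)CC1` reaches only a limit of the assay, > 4 mg/kg. Compound 3 `COc1cc(N)c(Cl)cc1NC(=O)C1CCN(CC2CCCC2)CC1` likewise reaches only a limit, > 10 mg/kg. Compound 4 `COc1cc(N)c(Cl)cc1NC(=O)C1CCN(CC2CCCCCC2)CC1` has not yet been measured; it differs from compound 2 by cycloheptyl in place of 2-chlorophenyl on a saturated chain carbon bound to an amine nitrogen in a ring. Among the measured steps, the exchange of an aromatic ring for a saturated ring appears once: an at least 4.1-fold higher number from compound 1 to compound 3 (0.61 log units; beyond the scatter). The step that the two limits leave unreadable from compound 2 to compound 3 cannot be read. With the rise an at least 4.1-fold higher number from compound 1 to compound 3 (0.61 log units; beyond the scatter) as the closest guide, compound 4 is expected to show the step that the limit leaves unreadable from compound 2 to compound 4, and its number will probably again come out as a limit. Compound 4 is therefore estimated at 12 mg/kg, within 4 mg/kg to 40 mg/kg.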

Compound 4, dose for half-maximal effect: > 10 mg/kg
Compound 4 was reported as a limit; the forecaster's own chance of this, stated with the estimate: 70%; the middle value lies beyond the limit too.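

In this assay, cycloheptyl in place of 3-methylphenyl gives an at least 4.1-fold higher number from compound 1 to compound 4 (0.61 log units; beyond the scatter), so a second saturated ring joins cyclopentyl in ending beyond the scatter from compound 1. Compound 2, which keeps an aromatic ring, also gives only a limit, > 4 mg/kg, so an aromatic ring alone does not secure a readable number. The steps from compound 2 and from compound 3 to compound 4 cannot be read, and compound 4 shares its limit with compound 3: the limit of > 10 mg/kg in this assay, at which 2 of the 4 values shown sit.

On these data alone, how far either saturated ring lies past that limit stays open, so the two ring sizes cannot be ranked. As far as these compounds go, what cyclohexyl or a methoxyphenyl group would give at this place also stays open.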